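Working notes: the step from compound 3 to compound 4

The source may report more compounds than this note shows. Statements on the series, on what has been measured and on what is new or still open speak of the compounds shown alone.

Measured in a functional assay for inhibition, with Homo sapiens as the target; a higher number here means weaker binding, a lower number tighter binding:
- compound 1 `N#Cc1ccc(C2OCC(C/C=C\CCC(=O)O)C(c3cccnc3)O2)cc1` gives 1290 nM
- compound 2 `O=C(O)CC/C=C\CC1COC(c2cccs2)OC1c1cccnc1` gives 1000 nM
- compound 3 `CC(C)(Oc1ccccc1)C1OCC(C/C=C\CCC(=O)O)C(c2cccnc2)O1` gives 75.9 nM

Compound 3 stands lowest of the three numbers. Compounds 1 and 2 lie together, a 1.3-fold lower number from compound 1 to compound 2 (0.11 log units; within the scatter), whereas a 17-fold lower number from compound 1 to compound 3 (1.23 log units; beyond the scatter) and a 13-fold lower number from compound 2 to compound 3 (1.12 log units; beyond the scatter) are both large. Compound 4 `CC(C)(C1OCC(C/C=C\CCC(=O)O)C(c2cccnc2)O1)S(=O)(=O)c1ccccc1` has not yet been measured. It differs from compound 3 in one place: phenylsulfonyl in place of phenoxy on a saturated chain carbon bound to two saturated chain carbons and a saturated ring carbon. Among the compounds with values here, no measured step exchanges one group for another on that saturated chain carbon; the two large steps concern a saturated ring carbon and so do not bear directly on this change. Within the data shown here, the only footing is that compound 3, whose group here holds the phenyl ring that compound 4 retains, gives the lowest number. Among the measured compounds shown here, with no direct precedent, the expectation for compound 4 is a number close to that of compound 3, with no direction beyond the scatter, and a wide range. Compound 4 is therefore estimated at 120 nM, between 30 nM and 500 nM, a step of a 1.6-fold higher number from compound 3 to compound 4 (0.20 log units; within the scatter) expected.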

Compound 4, dissociation constant: 3160 nM
For compound 4 the middle estimate is 26-fold (1.42 log units) below the measured one; measured number above the stated range.
By their numbers in this assay, from the lowest: compound 3; then compounds 2 and 1 (each within the scatter of the next); then compound 4.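

Phenylsulfonyl in place of phenoxy on a saturated chain carbon bound to two saturated chain carbons and a saturated ring carbon gives a 42-fold higher number from compound 3 to compound 4 (1.62 log units; beyond the scatter) in this assay and places compound 4 last in the series. Within the data shown here, this is the first reading at this chain carbon, since the earlier steps all concerned a saturated ring carbon, and it shows that keeping the phenyl ring does not by itself preserve the low number of compound 3. No measurement available here bears on the origin of this step.

The compounds shown carry only phenoxy and phenylsulfonyl on this carbon, so it remains open whether phenylthio, benzyl or anilino would stay with compound 3 or fall with compound 4. Also open, from the compounds shown here alone, is whether a group without a phenyl ring, such as a methoxy group or a longer alkyl chain, is accepted on this carbon.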